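The source may report more compounds than this note shows. Statements on the series, on what has been measured and on what is new or still open speak of the compounds shown alone.

Measured so far in a physicochemical assay for solubility, with a stated time of 24 h, at pH 4.5; a lower number here means a less soluble compound, a higher number a more soluble compound:
- Compound 1 `O=C(NC[C@@H]1[C@H]2CN(C(=O)C3CC3c3cc(Cl)cc(Cl)c3)C[C@@H]12)c1ccc2[nH]c(=O)oc2c1`: < 1 ug/mL, a limit of the assay and not a number.
- Compound 2 `N#Cc1cc(COC(=O)N2C[C@@H]3[C@@H](CNC(=O)N4CCc5[nH]nnc5C4)[C@@H]3C2)cc(C(=O)OC(F)(F)F)c1`: 26 ug/mL.

Going by the values given here, compound 2, at 26 ug/mL, holds the only actual number so far in this assay. Among the compounds with values here, for compound 1, the sole reading is the limit of < 1 ug/mL in this assay, at which 1 of the 2 values shown sits, which is a limit.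

Compound 3 `N#Cc1cc(COC(=O)N2C[C@@H]3[C@@H](CNC(=O)N4CCc5c(O)noc5C4)[C@@H]3C2)cc(C(=O)OC(F)(F)F)c1` differs from compound 2 in one place, on a carbonyl carbon whose other neighbour is an amide-type nitrogen: a group of 10 heavy atoms (6 carbon, 2 nitrogen, 2 oxygen; one five-membered aromatic ring with 2 hetero atoms, one six-membered non-aromatic ring with 1 hetero atom) in place of a group of 9 heavy atoms (5 carbon, 4 nitrogen; one five-membered aromatic ring with 3 hetero atoms, one six-membered non-aromatic ring with 1 hetero atom), on a carbonyl carbon. Within the data shown here, both groups contain a five-membered aromatic ring and a six-membered non-aromatic ring, but no measured pair shows what this exchange does. Among the measured compounds shown here, the only anchor is compound 2 at 26 ug/mL. The expected change, a 1.2-fold higher number from compound 2 to compound 3 (0.06 log units; within the scatter), is therefore no larger than the usual scatter, and its direction is left open. For compound 3, the estimated value is 30 ug/mL, with an expected range of 10 ug/mL to 90 ug/mL.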

Compound 3, solubility: < 1 ug/mL
Compound 3 ended at the assay's limit (the forecaster's own chance of this, stated with the estimate: 4%); middle value at least 30-fold (1.47 log units) from the limit.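

Until now, nothing showed what a change at this place does. In this assay, exchanging one group for the other on a carbonyl carbon whose other neighbour is an amide-type nitrogen gives an at least 26-fold lower number from compound 2 to compound 3 (1.41 log units; beyond the scatter). Both groups contain a five-membered aromatic ring and a six-membered non-aromatic ring, so this shared ring makeup does not keep the reading in place. Compound 3 gives a limit of the assay and not a number, the same reading as one other compound shown: the limit of < 1 ug/mL in this assay, at which 2 of the 3 values shown sit.

The compounds shown do not separate the effect of the different hetero atoms in the five-membered ring from that of the other differences between the two groups. They also leave open how a five-membered aromatic ring carrying an amine or a carboxylic acid would read in this assay.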